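Nitro for Methoxy on a Shared Amide Core

The source may report more compounds than this note shows. Statements on the series, on what has been measured and on what is new or still open speak of the compounds shown alone.

Compound 1 `COc1ccccc1NC(=O)c1ccc2cccc(O)c2n1` belongs to a small set of amides built on one shared core and tested in an ADME assay on THP-1 cells (Homo sapiens) for cytotoxicity, read by WST assay, with a stated time of 24 h; a higher number here means a weaker inhibitor, a lower number a stronger inhibitor. In this assay compound 1 gives > 30000 nM, which is a limit of the assay rather than a number. Compound 2 `COc1ccc(NC(=O)c2ccc3cccc(O)c3n2)cc1` gives > 30000 nM in this assay, again a limit. Compound 3 `O=C(Nc1cccc(Br)c1)c1ccc2cccc(O)c2n1` gives > 30000 nM in this assay, also a limit. Compound 1 therefore stands exactly where its two companions stand, namely at the limit of > 30000 nM in this assay, at which 3 of the 3 values shown sit, and no pair of these compounds that differ in only one place has a measured step between them.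

Compound 4 `O=C(Nc1ccccc1[N+](=O)[O-])c1ccc2cccc(O)c2n1` has not yet been measured. It differs from compound 1 by nitro in place of methoxy on an aromatic carbon, in words nitro in place of methoxy on an aromatic carbon. Among the compounds with values here, no measured pair shows what this change does in this assay. Given that compound 1 sits at the limit of > 30000 nM in this assay, at which 3 of the 3 values shown sit, the expected step of a number no higher from compound 1 to compound 4 (the limit leaves the size open) is none beyond the scatter. Compound 4 is thus expected to give about 30000 nM in this assay, within a range from 15000 nM to 100000 nM, and most likely to be reported once more only as a limit.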

Compound 4, half-maximal inhibitory concentration: > 30000 nM
Compound 4 gave a limit, no number (the forecaster's own chance of this, stated with the estimate: 80%); the middle value lies on the limit itself.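

Compound 1 and compound 4 each give only a limit in this assay, so the step from methoxy to nitro cannot be read. The same holds across the whole set: the limit of > 30000 nM in this assay, at which 4 of the 4 values shown sit.

The compounds shown leave open where the true value of each one lies, and whether any change on the shared core would give a measurable number in this assay.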